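The source may hold more compounds than are shown below. What is called first, only, known or untested is meant among the compounds shown, and "the series" means these compounds.

Working notes on the series, cytotoxicity arm.

Compound 2 `CCn1cc(C(=O)N2N=C(c3cc4ccccc4o3)CC2c2ccccc2Cl)c(=O)c2ccc(C)nc21` is the reference point for this step. In an ADME assay on Vero cells (Chlorocebus sabaeus) for cytotoxicity, read by MTT assay, with a stated time of 72 h (a lower number here means a stronger inhibitor, a higher number a weaker inhibitor), compound 2 gives > 178000 nM, which is a limit of the assay rather than a number. Within the data shown here, the only neighbour measured so far is compound 1 `CCn1cc(C(=O)N2N=C(c3cc4ccccc4o3)CC2c2ccc(Cl)cc2)c(=O)c2ccc(C)nc21`. In this assay compound 1 gives > 160000 nM, likewise a limit. Among the measured compounds shown here, the one step available, a step that the two limits leave unreadable from compound 1 to compound 2, is therefore not readable in size or direction; all that is on hand is the limit of > 160000 nM in this assay, at which 1 of the 2 values shown sits, and (the limit of > 178000 nM in this assay, at which 1 of the 2 values shown sits), which together place both compounds at the top of the tested window.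

Compound 3 `CCn1cc(C(=O)N2N=C(c3cc4ccccc4o3)CC2c2ccc(OC)cc2)c(=O)c2ccc(C)nc21` is still to be measured. Its change from compound 2 is 4-methoxyphenyl in place of 2-chlorophenyl on a saturated ring carbon. For the measured compounds named here, no measured step bears on this change beyond the two limits, so no step beyond the scatter is expected in either direction, and a further limit is the most likely outcome. Compound 3 is expected to sit at about 200000 nM (range 90000 nM to 450000 nM), an estimated step that the limit leaves unreadable from compound 2 to compound 3.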

Compound 3, half-maximal inhibitory concentration: > 156000 nM
Compound 3: only a limit was reported; the forecaster's own chance of this, stated with the estimate: 80%; the middle value does not contradict the limit.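

In this assay compound 3 gives > 156000 nM, a limit of the assay. The steps from compound 1 and from compound 2 to compound 3 therefore cannot be read. Left open is where compound 1, compound 2 and compound 3 truly lie in this assay, and whether the group on the saturated ring carbon changes that at all.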